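Hydroxy removal from compound 2

A few compounds are considered here, and "the series" means these few. Any claim that something is new, unique, unknown or untested is made for them only; others in the source may bear on it.

In a physicochemical assay for solubility, using the shake flask method, with a stated time of 12 h (a lower number here means a less soluble compound, a higher number a more soluble compound), compound 1 (`O=C(/C=C/c1ccc(O)c(O)c1)CC(=O)/C=C/c1cccc(O)c1O`) gives 3800 nM and compound 2 (`O=C(/C=C/c1cccc(O)c1O)CC(=O)/C=C/c1cccc(O)c1O`) gives 5300 nM and these two values lie within the scatter of each other, so neither can be ranked over the other. Among the compounds with values here, compound 2 therefore stands level with the only other measured member of the series.

Compound 3 (`O=C(/C=C/c1ccccc1O)CC(=O)/C=C/c1cccc(O)c1O`) carries hydrogen in place of hydroxy on an aromatic carbon, ortho to a hydroxy group, turning 2,3-dihydroxyphenyl into 2-hydroxyphenyl (hydrogen in place of hydroxy on an aromatic carbon).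

Within the data shown here, only one measured step is available as a guide, and it removes no hydroxy group. Among the measured compounds shown here, that step (a 1.4-fold higher number from compound 1 to compound 2 (0.14 log units; within the scatter)) bears on the new change only indirectly, and no measured pair shows the removal itself. With that small step as the sole reference, no shift beyond the scatter is expected in this assay and no direction is firmly expected, so the range is kept wide. The expected change is small (a 1.2-fold lower number from compound 2 to compound 3 (0.07 log units; within the scatter)) and remains an estimate. For compound 3 the estimated value is 4500 nM (expected range 1800 nM to 10000 nM).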

Compound 3, solubility: 11000 nM
Estimate against measurement, compound 3: 2.4-fold (0.39 log units) below, outside the stated range (above it).
By their numbers in this assay, from the lowest: compounds 1 and 2 (each within the scatter of the next); then compound 3.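

In this assay, within the data shown here, the aromatic carbon ortho to a hydroxy group is the first place where a change clearly moves the number: hydrogen in place of hydroxy gives the step (a 2.1-fold higher number from compound 2 to compound 3 (0.32 log units; beyond the scatter)), whereas exchanging 3,4-dihydroxyphenyl for 2,3-dihydroxyphenyl stayed level (a 1.4-fold higher number from compound 1 to compound 2 (0.14 log units; within the scatter)). Compound 3 also separates from the 3,4-dihydroxyphenyl member (a 2.9-fold higher number from compound 1 to compound 3 (0.46 log units; beyond the scatter)), so the 2-hydroxyphenyl compound stands highest of the three, although both of its steps are modest. No measurement bears on the origin of this rise, and the step stands here as an observation only.

The compounds shown leave open whether the rise is specific to hydrogen at this carbon or would also appear with a methoxy group, a fluorine atom or an amine in the same place. Going by these compounds, it also remains open whether the same removal on the other 2,3-dihydroxyphenyl group would move the number in the same direction, or whether the step depends on the group carried at the far end of the chain.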